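The compounds below may be only part of what the source reports. "The series", "measured", "known", "first", "only" and "open" are said of these compounds alone.

Measured compounds:
- Compound 1 `O=C1/C(=C/c2ccccc2)NS(=O)(=O)c2ccccc21`: 1780 nM in an assay for inhibition of Intestinal-type alkaline phosphatase (Homo sapiens), read by spectrophotometry, with stated times of 10 min and 20 min; on this read-out lower numbers stand for stronger inhibition and higher numbers for weaker inhibition
- Compound 2 `COc1ccccc1/C=C1\NS(=O)(=O)c2ccccc2C1=O`: 1240 nM
- Compound 3 `O=C1/C(=C/c2ccccc2Br)NS(=O)(=O)c2ccccc21`: 7430 nM

Compound 3 carries the highest number of the three: the steps of a 4.2-fold higher number from compound 1 to compound 3 (0.62 log units; beyond the scatter) and a 6.0-fold higher number from compound 2 to compound 3 (0.78 log units; beyond the scatter) both lie beyond the scatter, so it is the weakest of the measured set. Compound 1 and compound 2 sit close together, and the step of a 1.4-fold lower number from compound 1 to compound 2 (0.16 log units; within the scatter) is within the scatter.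

Compound 4 `O=C1/C(=C/c2ccc(Br)cc2)NS(=O)(=O)c2ccccc21` differs from compound 3 by 4-bromophenyl in place of 2-bromophenyl on a double-bonded chain carbon bound to a double-bonded ring carbon. Within the data shown here, no measured pair shows this kind of rearrangement; the two steps that involve bromine, from compound 1 and from compound 2 to compound 3, both concern bromine put on the aromatic carbon that bears it in the 2-bromophenyl group, and both were modest rises in the number. How a bromine on the 4-bromophenyl group behaves is therefore not covered by any measured step, and the expectation rests on the observation that compound 3 is the weakest of the set and that a different placement of the same atoms may or may not keep that penalty.

Compound 4 is estimated at 3500 nM, with a range from 1000 nM to 12000 nM, which means an expected step of a 2.1-fold lower number from compound 3 to compound 4 (0.33 log units; beyond the scatter).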

Compound 4, half-maximal inhibitory concentration: 3690 nM
The estimate for compound 4 lay 1.1-fold (0.02 log units) below the measured number; low and high end bracket the measured number.
By their numbers in this assay, from the lowest: compounds 2 and 1 (each within the scatter of the next); then compounds 4 and 3 (each within the scatter of the next).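

In this assay, 4-bromophenyl in place of 2-bromophenyl on a double-bonded chain carbon bound to a double-bonded ring carbon gives a 2.0-fold lower number from compound 3 to compound 4 (0.30 log units; within the scatter), so this read-out does not separate the two bromine placements. Among these compounds, the penalty for bromine is therefore not confined to the 2-bromophenyl group: bromo in place of hydrogen on an aromatic carbon also gives a 2.1-fold higher number from compound 1 to compound 4 (0.32 log units; beyond the scatter), a modest step in the same direction as the one already seen with compound 3. No measurement available here explains how either bromine placement relates to these numbers.

The compounds shown leave open whether this rise belongs to bromine in particular or would also appear with fluoro, chloro, an amine or a carboxylic acid on the same aromatic ring. They also leave open whether methoxy, which in compound 2 stays within the scatter of compound 1, would behave the same way when carried in the place that bromine holds in the 4-bromophenyl group.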